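The source may report more compounds than this note shows. Statements on the series, on what has been measured and on what is new or still open speak of the compounds shown alone.

Measured so far in a functional assay on MDA-MB-231 cells (Homo sapiens) for cytotoxicity, read by MTT assay, with a stated time of 72 h; a higher number here means a weaker inhibitor, a lower number a stronger inhibitor:
compound 1 `O=C1c2c[n+]([O-])c3ccccc3c2C(=O)c2c1c1ccccc1n2Cc1cn([C@H]2C[C@H](O)[C@@H](CO)O2)nn1` gives 580 nM
compound 2 `CC1(C)O[C@@H](CO)[C@H](Cn2cc(Cn3c4c(c5ccccc53)C(=O)c3c[n+]([O-])c5ccccc5c3C4=O)nn2)O1` gives 680 nM
compound 3 `O=C1c2c[n+]([O-])c3ccccc3c2C(=O)c2c1c1ccccc1n2Cc1cn([C@@H]2C[C@H](O)[C@@H](CO)O2)nn1` gives 130 nM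

Compound 1 holds the second highest number of the three; its nearest neighbour is compound 2, reached by a 1.2-fold higher number from compound 1 to compound 2 (0.07 log units; within the scatter), and its furthest is compound 3, reached by a 4.5-fold lower number from compound 1 to compound 3 (0.65 log units; beyond the scatter). The drop to compound 3 rests on (the fact that compounds 1 and 3 differ only in the configuration as drawn). Compound 4 `O=C1c2c[n+]([O-])c3ccccc3c2C(=O)c2c1c1ccccc1n2Cc1cn([C@H]2O[C@H](CO)[C@@H](O)[C@H]2O)nn1` is unmeasured; it differs from compound 1 by 3,4-dihydroxy-5-(hydroxymethyl)oxolan-2-yl in place of 4-hydroxy-5-(hydroxymethyl)oxolan-2-yl on an aromatic nitrogen. For the measured compounds named here, the steps that bear on this change are the exchanges of the whole group, a 1.2-fold higher number from compound 1 to compound 2 (0.07 log units; within the scatter) and a 5.2-fold lower number from compound 2 to compound 3 (0.72 log units; beyond the scatter), and the configurational step a 4.5-fold lower number from compound 1 to compound 3 (0.65 log units; beyond the scatter). Exchange of the group shifted the number little in one case and modestly in another, so for compound 4 a step within the scatter or at most modest is expected, direction uncertain: the estimated step is a 1.2-fold lower number from compound 1 to compound 4 (0.06 log units; within the scatter). For compound 4 the expected value is 500 nM, with a range of 200 nM to 1500 nM.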

Compound 4, half-maximal inhibitory concentration: 1700 nM
Estimate against measurement, compound 4: 3.4-fold (0.53 log units) below, outside the stated range (above it).
By their numbers in this assay, from the lowest: compound 3; then compounds 1 and 2 (each within the scatter of the next); then compound 4.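

In this assay, the group on the aromatic nitrogen proves sensitive to a single added substituent: hydroxy in place of hydrogen on a saturated ring carbon gives the largest step in the series (a 13-fold higher number from compound 3 to compound 4 (1.12 log units; beyond the scatter)). Entry of 3,4-dihydroxy-5-(hydroxymethyl)oxolan-2-yl also raises the number against the other two groups (a 2.9-fold higher number from compound 1 to compound 4 (0.47 log units; beyond the scatter); a 2.5-fold higher number from compound 2 to compound 4 (0.40 log units; beyond the scatter)), leaving compound 4 highest of the four. Nothing measured here accounts for this rise.

From the compounds shown here alone, whether an amine or a methoxy group in place of that added hydroxy would give a similar step remains open.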